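This account rests on a few compounds, and the source may have more. Where it says the series, first, only, none or still open, it means among the compounds named here.

In a functional assay on A549 cells (Homo sapiens) for inhibition, read by sulforhodamine B assay, with a stated time of 72 h (a higher number here means a weaker inhibitor, a lower number a stronger inhibitor), three compounds have been measured:

- compound 1 `Nc1sc(-c2ccc(Cl)cc2)c(-c2ccc(Cl)cc2)c1C(=O)Nc1ccccc1`: 25000 nM
- compound 2 `CCOC(=O)Nc1sc(-c2ccc(Cl)cc2)c(-c2ccc(Cl)cc2)c1C(=O)NC1CC1`: 39800 nM
- compound 3 `Nc1sc(-c2ccc(Cl)cc2)c(-c2ccc(Cl)cc2)c1C(=O)NC1CCC(O)CC1`: 250 nM

Compound 3 has the lowest number of the three, and its gaps to compound 1 and compound 2 both lie beyond the scatter. The next compound, compound 4 `Nc1sc(-c2ccc(Cl)cc2)c(-c2ccc(Cl)cc2)c1C(=O)N1CCCC1`, changes it as follows: pyrrolidin-1-yl in place of (4-hydroxycyclohexyl)amino on a carbonyl carbon. In words, pyrrolidin-1-yl stands in place of (4-hydroxycyclohexyl)amino on a carbonyl carbon.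

Going by the values given here, one measured step bears on this change: a 100-fold lower number from compound 1 to compound 3 (2.00 log units; beyond the scatter). That large step came with 4-hydroxycyclohexyl in place of phenyl on the same amide-type nitrogen. Among the compounds with values here, compound 4 gives up the 4-hydroxycyclohexyl group, and no measured compound carries pyrrolidin-1-yl, so the data do not test the new group directly. On the evidence of compound 3 against compound 1, at 25000 nM, a large move back towards a higher number is expected in this assay.

The expected step is a 32-fold higher number from compound 3 to compound 4 (1.51 log units; beyond the scatter). For compound 4 the estimated value is 8000 nM, with an expected range from 1500 nM to 40000 nM.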

Compound 4, half-maximal inhibitory concentration: 890 nM
Beside the measured number, compound 4's estimate is 9.0-fold (0.95 log units) above it; measured number below the stated range.
By their numbers in this assay, from the lowest: compound 3; then compound 4; then compounds 1 and 2 (each within the scatter of the next).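

In this assay, the step of a 3.6-fold higher number from compound 3 to compound 4 (0.55 log units; beyond the scatter) is modest, so most of the gain seen on leaving anilino at this carbonyl carbon survives without the 4-hydroxycyclohexyl group. The step of a 28-fold lower number from compound 1 to compound 4 (1.45 log units; beyond the scatter) is large, which shows that neither the hydroxyl nor the amide hydrogen is needed for a number far lower than that of compound 1, although compound 3 still keeps a lead beyond the scatter. No measurement shown here explains either step.

The compounds shown leave open whether plain cyclohexylamino would match 4-hydroxycyclohexylamino, and so how much of the remaining gap belongs to the hydroxyl. They also leave open whether 3-hydroxypyrrolidin-1-yl, piperidin-1-yl or morpholin-4-yl on the same carbonyl carbon would close that gap.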